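Halophenyl Swap on the Anilino Series

The source may hold more compounds than are shown below. What is called first, only, known or untested is meant among the compounds shown, and "the series" means these compounds.

Measured compounds:
- compound 1, `O=C1C(Nc2ccc(Br)cc2)=CC(=O)c2c1nc1n2[C@H]2OC[C@@H](O)[C@H]2OC1`: 4330 nM
- compound 2, `O=C1C=C(N2CCCCC2)C(=O)c2c1nc1n2[C@H]2OC[C@@H](O)[C@H]2OC1`: > 8000 nM

Among the compounds with values here, in a functional assay on MCF7 cells (Homo sapiens) for inhibition, read by sulforhodamine B assay (on this read-out higher numbers stand for weaker inhibition and lower numbers for stronger inhibition), compound 1 gives 4330 nM, the only number among the measured compounds. Compound 2 gives > 8000 nM, which is a limit of the assay and not a number (the limit of > 8000 nM in this assay, at which 1 of the 2 values shown sits). Compound 3, `O=C1C(Nc2cccc(Cl)c2)=CC(=O)c2c1nc1n2[C@H]2OC[C@@H](O)[C@H]2OC1`, is not yet measured. It differs from compound 1 by 3-chlorophenyl in place of 4-bromophenyl on an amine nitrogen. Within the data shown here, with no measured pair of this kind to lean on, the step is expected to be small, none beyond the scatter, in either direction: a 1.0-fold higher number from compound 1 to compound 3 (0.02 log units; within the scatter). Compound 3 is therefore estimated at 4500 nM, in the range 1800 nM to 11000 nM.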

Compound 3, half-maximal inhibitory concentration: 2970 nM
Compound 3: the middle estimate sits 1.5-fold (0.18 log units) above what was measured; the measured number falls inside the stated range.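

On the amine nitrogen, 3-chlorophenyl in place of 4-bromophenyl gives a 1.5-fold lower number from compound 1 to compound 3 (0.16 log units; within the scatter) in this assay. This exchange of one halophenyl group for another therefore does not separate compound 1 and compound 3 on this read-out. No measurement shown gives a reason for this step. The halogen and its location on the phenyl ring changed together in this single step, so neither can be read alone. On these data alone, whether an unsubstituted phenyl, a methoxyphenyl or a benzyl group on this nitrogen would read differently remains open.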